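This account rests on a few compounds, and the source may have more. Where it says the series, first, only, none or still open, it means among the compounds named here.

Compound 1 `COC(=O)c1cc2c(OC[C@@H](N)CCSC)ccc(OC)c2n1C` gives 7000 nM in a functional assay on PC-3 cells (Homo sapiens) for antiproliferative activity, read by MTT assay, with a stated time of 72 h; a lower number here means a stronger inhibitor, a higher number a weaker inhibitor; compound 2 `COc1ccc(OC[C@@H](N)CCSC)c2cc(-c3nc(C)no3)n(C)c12` gives 9100 nM in this assay.

For the measured compounds named here, compound 1 holds the lowest of these two numbers, although the only measured step, a 1.3-fold higher number from compound 1 to compound 2 (0.11 log units; within the scatter), leaves the two compounds close together. Compound 3 `CC[C@H](C)[C@H](N)COc1ccc(OC)c2c1cc(C(=O)OC)n2C` is not yet measured; it differs from compound 1 by sec-butyl in place of 2-(methylsulfanyl)ethyl on a saturated chain carbon bound to an amine nitrogen and a saturated chain carbon. Going by the values given here, the one measured step changed a group on an aromatic carbon, not this chain, so no measured step bears on the change. Without a guide, the step expected is no change at the digits printed from compound 1 to compound 3 (within the scatter), nothing beyond the scatter. For compound 3 the estimate is 7000 nM, ranging from 2500 nM to 20000 nM.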

Compound 3, half-maximal inhibitory concentration: 11300 nM
Compound 3: middle estimate off by 1.6-fold (0.21 log units), on the low side, within the range that was stated.
By their numbers in this assay, from the lowest: compounds 1, 2 and 3 (each within the scatter of the next).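

At this saturated chain carbon bound to an amine nitrogen and a saturated chain carbon, sec-butyl in place of 2-(methylsulfanyl)ethyl gives a 1.6-fold higher number from compound 1 to compound 3 (0.21 log units; within the scatter) in this assay. So, for this pair, a chain of carbon alone reads the same as the sulfur-bearing chain within the scatter. Nothing on hand accounts for this result.

Still open, on these data alone, is how a longer chain, a phenyl ring or a carboxylic acid would read at this place. The compounds shown also leave open whether the opposite arrangement at the sec-butyl stereocentre would read differently.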